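Changing the aryl group while the methyl stays

The compounds below may be only part of what the source reports. "The series", "measured", "known", "first", "only" and "open" are said of these compounds alone.

Of the compounds shown here, three sharing one core have been measured in an ADME assay on CHO cells (Cricetulus griseus) for cytotoxicity, read by MTT assay; on this read-out higher numbers stand for lower toxicity in this test and lower numbers for higher toxicity in this test. Compound 1 `CN1CCN(C2CCN(c3nccc4[nH]c(-c5cccc(OC(F)(F)F)c5)nc34)CC2)CC1` gives 3000 nM, compound 2 `CN1CCN(C2CCN(c3nccc4[nH]c(-c5ccc(F)c(C(F)(F)F)c5)nc34)CC2)CC1` gives 4800 nM and compound 3 `Fc1ccc(-c2nc3c(N4CCC(N5CCNCC5)CC4)nccc3[nH]2)cc1C(F)(F)F` gives 34000 nM. Compound 2 therefore holds the second highest of the three numbers. Its nearest neighbour lies only a 1.6-fold higher number from compound 1 to compound 2 (0.20 log units; within the scatter) away, so those two cannot be told apart, while the furthest lies at a 7.1-fold higher number from compound 2 to compound 3 (0.85 log units; beyond the scatter).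

Compound 4 `CN1CCN(C2CCN(c3nccc4[nH]c(-c5cccc(C#N)c5)nc34)CC2)CC1` has not been measured yet. It keeps the methyl on the ring amine nitrogen and differs from compound 2 in one place: 3-cyanophenyl in place of 4-fluoro-3-(trifluoromethyl)phenyl on an aromatic carbon. Within the data shown here, the closest guide is the one measured swap of this aromatic group, a 1.6-fold higher number from compound 1 to compound 2 (0.20 log units; within the scatter). The larger step, a 7.1-fold higher number from compound 2 to compound 3 (0.85 log units; beyond the scatter), goes with hydrogen in place of that methyl, a change compound 4 does not make, so it offers little guidance here. Among the measured compounds shown here, one swap is thin evidence, and no measured compound carries a nitrile.

The expected result is no change beyond the scatter, an estimated 1.0-fold higher number from compound 2 to compound 4 (0.02 log units; within the scatter). For compound 4 the estimated value is 5000 nM, with an expected range of 2000 nM to 12000 nM.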

Compound 4, half-maximal cytotoxic concentration: 16000 nM
The estimate for compound 4 lay 3.2-fold (0.51 log units) below the measured number, outside the stated range (above it).
By their numbers in this assay, from the lowest: compounds 1 and 2 (each within the scatter of the next); then compound 4; then compound 3.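

Among these compounds, the aryl group on the aromatic carbon between two ring nitrogen atoms had looked unimportant in this assay, since the one earlier swap there stayed within the scatter, but this result shows that the group can shift the number while the methyl stays in place. With 3-cyanophenyl in place of 4-fluoro-3-(trifluoromethyl)phenyl there is a 3.3-fold higher number from compound 2 to compound 4 (0.52 log units; beyond the scatter), and cyano in place of trifluoromethoxy gives a 5.3-fold higher number from compound 1 to compound 4 (0.73 log units; beyond the scatter), both beyond the scatter and both toward lower toxicity in this test. So a change at this position alone moves the read-out in the same direction as the earlier change on the ring amine nitrogen, and no measurement here explains why the nitrile-bearing compound stands higher.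

With a single nitrile compound, the data cannot separate an effect of the nitrile itself from the loss of the fluorinated groups, and a methoxy group, a primary amide or a carboxylic acid on the same phenyl ring could tell these apart. On these data alone, it also remains open whether 3-cyanophenyl would raise the number further when combined with hydrogen in place of the methyl on the ring amine nitrogen.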